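A Hydroxyphenyl Variant of a Weakly Active Thiazolidine Amide

The source may hold more compounds than are shown below. What is called first, only, known or untested is meant among the compounds shown, and "the series" means these compounds.

Compound 3 `CCCCCCCCCCCCCCCCCCNC(=O)[C@H]1CSC(c2cccnc2)N1` gives 10500 nM in a functional assay on RH7777 cells (Homo sapiens) for antiproliferative activity against RH7777 (Rattus norvegicus), read by sulforhodamine B assay; a lower number here means a stronger inhibitor, a higher number a weaker inhibitor. Of the two numbers shown it is nominally the lower, yet compound 1 `CCCCCCCCCCCCCCCCCCNC(=O)[C@H]1CSC(CCCCCCCCCCCC)N1` gives about 20000 nM, and the step of a 1.9-fold lower number from compound 1 to compound 3 (0.28 log units; within the scatter) cannot separate the two. Compound 2 `CCCCCCCCCCCCCCCCCCNC(=O)[C@H]1CSC(C2CCCCC2)N1` reaches only a limit of the assay, > 20000 nM. The step of an at least 1.9-fold lower number from compound 2 to compound 3 (0.27 log units; that floor lies within the scatter) therefore has a floor that also falls inside the scatter. Compound 4 `CCCCCCCCCCCCCCCCCCNC(=O)[C@H]1CSC(c2cccc(O)c2)N1` differs from compound 3 in one place: 3-hydroxyphenyl in place of pyridin-3-yl on a saturated ring carbon. Every measured step swapped the group on this same saturated ring carbon, and none shifted the number beyond the scatter. The change to compound 4 is thus expected to be small, a 1.1-fold lower number from compound 3 to compound 4 (0.02 log units; within the scatter). Compound 4 is estimated at 10000 nM, between 4000 nM and 25000 nM.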

Compound 4, half-maximal inhibitory concentration: 31000 nM
For compound 4 the middle estimate is 3.1-fold (0.49 log units) below the measured one; measured number outside the range, above it.
By their numbers in this assay, from the lowest: compounds 3, 1 and 4 (each within the scatter of the next, the first and the last beyond it).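

For the compounds shown here, on this saturated ring carbon, a 3.0-fold higher number from compound 3 to compound 4 (0.47 log units; beyond the scatter) in this assay is the one step beyond the scatter, so two six-membered aromatic rings need not read alike here. Dodecyl and 3-hydroxyphenyl stay unseparated, with a 1.6-fold higher number from compound 1 to compound 4 (0.19 log units; within the scatter) as their step. Compound 2 carries a limit of the assay, so its step to compound 4 cannot be read.

The compounds shown do not tell the loss of the ring nitrogen apart from the gain of the hydroxyl, which plain phenyl would do. As far as these compounds go, how an amine or a carboxylic acid on that aromatic ring would read also stays open.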